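Swapping the Five-Membered Ring on the Shared Core

The source may hold more compounds than are shown below. What is called first, only, known or untested is meant among the compounds shown, and "the series" means these compounds.

Three compounds share a core and differ at two ends. Compound 2 `COc1cc(N2CCN(C(=O)N[C@@H](C)c3cccc4ccccc34)CC2)ccc1-n1cc(C)nn1` gives 230 mL.min-1.g-1 in an ADME assay on microsomes from liver (Rattus norvegicus) for metabolic stability, read by LC-MS (a higher number here means faster removal of the compound, a lower number slower removal), the highest of the three numbers. Compound 3 `COc1cc(N2CCN(C(=O)Cn3ncc4ccccc43)CC2)ccc1-c1cnc(C)o1` gives 77 mL.min-1.g-1 in this assay, and compound 1 `COc1cc(N2CCN(C(=O)Cn3cnc4cccc(C(F)(F)F)c43)CC2)ccc1-c1cnc(C)o1` gives 7 mL.min-1.g-1; both gaps from compound 2 lie beyond the scatter. Compound 4 `COc1cc(N2CCN(C(=O)N[C@@H](C)c3cccc4ccccc34)CC2)ccc1-c1cnc(C)o1` is not yet measured; it differs from compound 2 only by 2-methyl-1,3-oxazol-5-yl in place of 4-methyl-1H-1,2,3-triazol-1-yl on an aromatic carbon. On these data alone, compounds 1 and 3 carry that same oxazole ring, yet they also differ from compound 2 at the other end, so how much of their lower numbers comes from the ring alone is unknown. A modest fall in this assay, possibly none beyond the scatter, is expected, giving an estimated step of a 1.9-fold lower number from compound 2 to compound 4 (0.28 log units; within the scatter). Compound 4 is expected to give 120 mL.min-1.g-1, within a range from 50 mL.min-1.g-1 to 300 mL.min-1.g-1.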

Compound 4, intrinsic clearance in microsomes: 130 mL.min-1.g-1
Beside the measured number, compound 4's estimate is 1.1-fold (0.03 log units) below it; low and high end bracket the measured number.
By their numbers in this assay, from the lowest: compound 1; then compounds 3, 4 and 2 (each within the scatter of the next, the first and the last beyond it).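

With the urea end of the molecule held fixed, the ring on the aromatic carbon ortho to a methoxy group can now be read on its own. In this assay, 2-methyl-1,3-oxazol-5-yl in place of 4-methyl-1H-1,2,3-triazol-1-yl gives a 1.8-fold lower number from compound 2 to compound 4 (0.25 log units; within the scatter) and this lies within the usual scatter, so this assay does not separate the two rings on this core. On these data alone, whether a different group here, such as an amine or a carboxylic acid, would move the number beyond the scatter remains open. No measurement at hand offers a reason for this result.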